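The source may hold more compounds than are shown below. What is called first, only, known or untested is meant among the compounds shown, and "the series" means these compounds.

Compound 1 `CCCCC(=O)N(Cc1ccc(OC)c(O)c1)c1cc(OC)c(OC)c(OC)c1` gives 300 nM in a functional assay on KYSE-450 cells (Homo sapiens) for inhibition, read by MTT assay, with a stated time of 48 h (a lower number here means a stronger inhibitor, a higher number a weaker inhibitor), the lowest of the three numbers recorded. Compound 2 `C/C=C/C(=O)N(Cc1cc(OC)c(OC)c(OC)c1)c1ccc(OC)c(O)c1` gives 9160 nM and compound 3 `COc1ccc(N(Cc2cc(OC)c(OC)c(OC)c2)C(=O)CCl)cc1O` gives 29800 nM. The one step shown, a 3.3-fold higher number from compound 2 to compound 3 (0.51 log units; beyond the scatter), swaps the acyl group on a carbonyl carbon, as does the step to compound 4 `COc1ccc(CN(C(=O)C(C)C)c2cc(OC)c(OC)c(OC)c2)cc1O`, which differs from compound 1 by isopropyl in place of butyl on a carbonyl carbon. That step was modest, but it involves a different acyl pair on a differently arranged core, so it only loosely guides this case. A small loss is therefore expected, with compound 4 estimated at 450 nM (range 200 nM to 1200 nM), a step of a 1.5-fold higher number from compound 1 to compound 4 (0.18 log units; within the scatter).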

Compound 4, half-maximal inhibitory concentration: 390 nM
For compound 4 the middle estimate is 1.2-fold (0.06 log units) above the measured one; measured number inside the range.
By their numbers in this assay, from the lowest: compounds 1 and 4 (each within the scatter of the next); then compound 2; then compound 3.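

In this assay, isopropyl in place of butyl on a carbonyl carbon gives a 1.3-fold higher number from compound 1 to compound 4 (0.11 log units; within the scatter), so on the core of compound 1 these two acyl chains cannot be told apart. This is the first step shown on that core, and it differs from the larger 3.3-fold higher number from compound 2 to compound 3 (0.51 log units; beyond the scatter), which lies on another core. Nothing measured here accounts for the two chains reading alike.

On these data alone, whether a longer chain, a cyclopropyl group or an amine at this carbonyl carbon would read the same remains open. So does whether butyl and isopropyl would also match on the core of compound 2.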